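Swapping a Methylpiperidine Amide for a Tetrahydroisoquinoline Amide

The source may hold more compounds than are shown below. What is called first, only, known or untested is meant among the compounds shown, and "the series" means these compounds.

Measured so far:
Compound 1, `CN(Cc1cccc(F)c1)C(=O)CN(C)C(=O)c1ccc(S(C)(=O)=O)c([N+](=O)[O-])c1`: in an assay on isolated protein for inhibition of thyroid hormone receptor alpha (Homo sapiens), read by fluorescence polarization (on this read-out higher numbers stand for weaker inhibition and lower numbers for stronger inhibition), compound 1 gives > 60000 nM, a limit of the assay rather than a number.
Compound 2, `CC1CCN(C(=O)CN(C)C(=O)c2ccc(S(C)(=O)=O)c([N+](=O)[O-])c2)CC1`: in this assay compound 2 gives > 60000 nM, again a limit of the assay.

Among the compounds with values here, compound 2 therefore stands at the limit, and so does the one other value shown, as the limit of > 60000 nM in this assay, at which 2 of the 2 values shown sit, records. Within the data shown here, the single measured step, a step that the two limits leave unreadable from compound 1 to compound 2, cannot be read, since both ends are limits.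

Compound 3, `CN(CC(=O)N1CCc2ccccc2C1)C(=O)c1ccc(S(C)(=O)=O)c([N+](=O)[O-])c1`, is not yet measured. It differs from compound 2 by 1,2,3,4-tetrahydroisoquinolin-2-yl in place of 4-methylpiperidin-1-yl on a carbonyl carbon. Among the measured compounds shown here, no measured step reports a change at this carbonyl that gave a readable number, so there is no basis for expecting a step of any particular size or direction in this assay. Compound 3 is therefore expected to stay at the limit, with the estimated step of a number no higher from compound 2 to compound 3 (the limit leaves the size open) meaning no readable change. The estimate for compound 3 in this assay is 60000 nM, with a range from 20000 nM to 200000 nM, and most likely the assay will again report only a limit.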

Compound 3, half-maximal inhibitory concentration: > 60000 nM
Compound 3 ended at the assay's limit; the forecaster's own chance of this, stated with the estimate: 85%; the middle value sits exactly at the limit.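

In this assay compound 3 gives > 60000 nM, a limit of the assay and not a number. Within the data shown here, compound 1 and compound 2 also stand at a limit, so no step among compound 1, compound 2 and compound 3 can be read. The shared standing is: the limit of > 60000 nM in this assay, at which 3 of the 3 values shown sit.

These compounds leave open whether any group on this carbonyl carbon gives a readable inhibition, and how the three groups rank.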